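The source may report more compounds than this note shows. Statements on the series, on what has been measured and on what is new or still open speak of the compounds shown alone.

In an assay on BAF cells for inhibition of ribosomal protein S6 kinase alpha-2 (Mus musculus) (on this read-out lower numbers stand for stronger inhibition and higher numbers for weaker inhibition), the shared core carries a methoxy-substituted aminoaryl group on one side and a fluoro-methoxyphenyl on the other. Compound 1 `COc1cccc(Nc2nc3cccc(-c4c(F)cccc4OC)c3o2)n1` is reported only as a limit, > 20000 nM, and the limit of > 20000 nM in this assay, at which 1 of the 2 values shown sits, holds for it. Compound 2 `COc1cc(Nc2nc3cccc(-c4c(F)cccc4OC)c3o2)cc(OC)c1OC` gives 2600 nM in this assay, which is the only actual number shown for the series. Compound 3 `COc1cc(Nc2nc3cccc(-c4c(F)cccc4OC)c3o2)cc(OC)c1` has not yet been measured in this assay. It differs from compound 2 by hydrogen in place of methoxy on an aromatic carbon, ortho to two methoxy groups and para to a large group. Among the compounds with values here, no measured step of this kind is available, so the size of the change is uncertain; the expectation is for a step from compound 2 to compound 3 of a 1.3-fold higher number from compound 2 to compound 3 (0.13 log units; within the scatter), mostly not beyond the usual scatter. Compound 3 is estimated at 3500 nM, within 1000 nM to 12000 nM.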

Compound 3, half-maximal inhibitory concentration: 17200 nM
The estimate for compound 3 lay 4.9-fold (0.69 log units) below the measured number; the measured number lies above the stated range.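

In this assay the methoxy on this aromatic carbon, ortho to two methoxy groups and para to a large group, turns out to matter: putting hydrogen in its place brings a 6.6-fold higher number from compound 2 to compound 3 (0.82 log units; beyond the scatter) and so carries the number well past the usual scatter. Within the data shown here, this is the first measured reading of this change, and it shows that the other two methoxy groups alone do not keep the number of compound 2. It rests on a single pair of compounds, however, and nothing available gives a reason for the size of the step.

From the compounds shown here alone, whether a hydroxyl, a fluorine or an ethoxy group on the same carbon would stand closer to methoxy or to hydrogen remains open. Also open, going by these compounds, is whether the step would recur with the other methoxy groups changed or on a different core.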